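The source may hold more compounds than are shown below. What is called first, only, known or untested is meant among the compounds shown, and "the series" means these compounds.

Among the compounds with values here, the three compounds measured so far share one core. Compound 1 `Nc1n[nH]c2cc(-c3cccnc3)[nH]c(=O)c12` gives 1% in an assay on isolated protein for inhibition of protein kinase C zeta type (Homo sapiens), read by mobility shift assay, tested at 30 uM; a higher number here means more inhibition at the concentration tested (going by the name of the read-out), a lower number less inhibition. In this assay compound 2 `Nc1n[nH]c2cc(-c3ccncc3)[nH]c(=O)c12` gives 10%, and compound 3 `COc1ccc(-c2cc3[nH]nc(N)c3c(=O)[nH]2)cc1` gives 7%. Compound 3 stands second highest of the three numbers; its nearest neighbour is compound 2, whose number lies within the scatter of its own, and the furthest is compound 1, whose number also lies within that scatter. The three values thus show no separation that a repeated measurement could not erase.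

Compound 4 `CN1CCN(c2ccc(-c3cc4[nH]nc(N)c4c(=O)[nH]3)cc2)CC1` differs from compound 3 in one place: 4-methylpiperazin-1-yl in place of methoxy on an aromatic carbon. Within the data shown here, no step between measured compounds has been recorded, so no size of effect can be drawn from this set. Because compound 3 sits at 7% and all three numbers cluster low, compound 4 is expected to stay near it, and the step of a number 1 percentage points higher from compound 3 to compound 4 (within the scatter) is expected to lie within the scatter. Compound 4 is estimated at 8% in this assay, within 0% to 25%.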

Compound 4, a percentage reported as inhibition, at one concentration (the size of the read-out at that concentration, not a potency): 35%
Compound 4: middle estimate off by 27 percentage points, on the low side; the whole stated range lies below it.
By their numbers in this assay, from the lowest: compounds 1, 3 and 2 (each within the scatter of the next); then compound 4.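

In this assay, 4-methylpiperazin-1-yl in place of methoxy on this aromatic carbon, para to a large group, gives a number 28 percentage points higher from compound 3 to compound 4 (beyond the scatter). Within the data shown here, this is the first step in the set that can be read as a difference, and it shows that this position is not indifferent to the group it carries, at least for this one change. Nothing shown explains why the number rises with this group.

As far as these compounds go, whether morpholine, an open-chain dimethylamino group or a piperazine without its methyl would give a similar step stays open, so the part of the 4-methylpiperazin-1-yl group that matters cannot be told. From the compounds shown here alone, the read-out is also the size of inhibition at a single concentration, so what this step means for potency remains open as well.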